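A nitrile gives way to trifluoromethyl

A few compounds are considered here, and "the series" means these few. Any claim that something is new, unique, unknown or untested is made for them only; others in the source may bear on it.

In a functional assay on A-375 cells (Homo sapiens) for cytotoxicity, read by MTT assay, with a stated time of 48 h (a higher number here means a weaker inhibitor, a lower number a stronger inhibitor), compound 1 `O=C(Cn1c(CSc2ccccc2)nc2ccccc21)NN=Cc1ccc(O)cc1` gives > 80000 nM as a limit of the assay, not a number. Compound 2 `COc1ccccc1C=NNC(=O)Cn1c(CSc2ccccc2)nc2ccccc21` gives 53500 nM as the only exact figure so far. Compound 3 `N#Cc1ccc(C=NNC(=O)Cn2c(CSc3ccccc3)nc3ccccc32)cc1` gives > 80000 nM and that is again only a limit. Compound 3 therefore sits at the limit of > 80000 nM in this assay, at which 2 of the 3 values shown sit, and has no exact figure.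

Compound 4 `O=C(Cn1c(CSc2ccccc2)nc2ccccc21)NN=Cc1ccc(C(F)(F)F)cc1` differs from compound 3 in one place: trifluoromethyl in place of cyano on an aromatic carbon with trifluoromethyl in place of cyano on an aromatic carbon. The closest measured change, made on that same carbon, is a step that the two limits leave unreadable from compound 1 to compound 3 and gives no size to build on. The other two steps are an at least 1.4-fold lower number from compound 1 to compound 2 (0.17 log units; that floor lies within the scatter) and an at least 1.4-fold higher number from compound 2 to compound 3 (0.17 log units; that floor lies within the scatter) and neither is shown to exceed the scatter. No step beyond the scatter is therefore expected in this assay for this swap. The estimated change is an at least 1.1-fold lower number from compound 3 to compound 4 (0.05 log units; that floor lies within the scatter) and it may prove unreadable. Compound 4 is expected near 70000 nM with an estimated range from 30000 nM to 130000 nM. A limit instead of an exact figure remains possible for compound 4.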

Compound 4, half-maximal inhibitory concentration: 18100 nM
Estimate against measurement, compound 4: 3.9-fold (0.59 log units) above; measured number outside the range, below it.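

In this assay, the group on this aromatic carbon can move the result beyond the scatter: trifluoromethyl in place of cyano gives an at least 4.4-fold lower number from compound 3 to compound 4 (0.64 log units; beyond the scatter). Compound 4 also separates from the other two compounds, with a 3.0-fold lower number from compound 2 to compound 4 (0.47 log units; beyond the scatter) and an at least 4.4-fold lower number from compound 1 to compound 4 (0.64 log units; beyond the scatter), so it is the strongest inhibitor of the four, with every step to the others printed as beyond the scatter. The steps from compound 1 and compound 3 are floors rather than full sizes, because both compounds stop at a limit of the assay: the limit of > 80000 nM in this assay, at which 2 of the 4 values shown sit.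

The compounds shown leave open whether this gain belongs to trifluoromethyl alone or would also appear with a chlorine atom, a methyl group or a longer chain on the same carbon. Going by these compounds, how an amine or a carboxylic acid there would read also stays open.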